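A few compounds are considered here, and "the series" means these few. Any claim that something is new, unique, unknown or untested is made for them only; others in the source may bear on it.

Three compounds have been measured in an assay on isolated protein for binding affinity to Alpha-1A adrenergic receptor (Rattus norvegicus), read by radioligand binding; a higher number here means a weaker inhibitor, a lower number a stronger inhibitor:
compound 1, `CS(=O)(=O)Nc1ccc(Cl)c2c1CCCC2c1c[nH]cn1`, giving 447 nM;
compound 2, `CCCS(=O)(=O)Nc1cccc2c1CCCC2c1c[nH]cn1`, giving 1700 nM;
compound 3, `CCS(=O)(=O)Nc1cccc2c1CCCC2c1c[nH]c(C)n1`, giving 794 nM.

Among these three numbers compound 2 stands highest, making it the weakest binder of the set: compound 3 lies below it by a step beyond the scatter, and compound 1 lies further below, also beyond the scatter. Compound 4, `O=C(Nc1cccc2c1CCCC2c1c[nH]cn1)C(F)(F)F`, has not yet been measured. It differs from compound 2 in one place: (trifluoromethyl)carbonyl in place of propylsulfonyl on a nitrogen on an aromatic ring. Among the compounds with values here, no two measured compounds differ by exactly this change, so the swap has no direct precedent here. A modest shift in this assay is expected, possibly staying within the scatter, and the step is estimated as a 1.3-fold lower number from compound 2 to compound 4 (0.12 log units; within the scatter). For compound 4 the expected value is 1300 nM, within a range from 350 nM to 5000 nM.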

Compound 4, inhibition constant: 166 nM
Estimate against measurement, compound 4: 7.8-fold (0.89 log units) above; measured number outside the range, below it.
By their numbers in this assay, from the lowest: compound 4; then compounds 1 and 3 (each within the scatter of the next); then compound 2.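

In this assay the group on this aromatic nitrogen clearly matters: (trifluoromethyl)carbonyl in place of propylsulfonyl gives a 10-fold lower number from compound 2 to compound 4 (1.01 log units; beyond the scatter), a large step and the first single-place change available here. A sulfonyl on this nitrogen is therefore not required for binding to this receptor. No measurement shown explains why the number falls. Still open, as far as these compounds go, is whether the carbonyl or the trifluoromethyl carries this shift, and how a plain acetyl or a trifluoromethylsulfonyl on the same nitrogen would compare.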